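Bromo for methoxy on the aryl of compound 2

The compounds below may be only part of what the source reports. "The series", "measured", "known", "first", "only" and "open" are said of these compounds alone.

Going by the values given here, compound 1 `COc1ccc(-c2csc(N3N=C(c4ccc(F)cc4)CC3c3ccc4c(c3)OCCO4)n2)cc1` and compound 2 `COc1ccc(C2=NN(c3nc(-c4ccc(Br)cc4)cs3)C(c3ccc4c(c3)OCCO4)C2)cc1` share one core and are the only measured members so far. In a functional assay on B16-F10 cells (Mus musculus) for antiproliferative activity, read by MTT assay, with a stated time of 48 h (on this read-out lower numbers stand for stronger inhibition and higher numbers for weaker inhibition), compound 1 gives 4430 nM. In this assay compound 2 gives 2520 nM. Compound 2 holds the lower of the two numbers, and compound 1 is the nearer one at a gap that stays within the usual scatter, so the two values read as alike. The two structures differ in more than one place, and no single change can be drawn from them.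

Compound 3 `Brc1ccc(C2=NN(c3nc(-c4ccc(Br)cc4)cs3)C(c3ccc4c(c3)OCCO4)C2)cc1` is the next member and has not yet been measured in this assay. It differs from compound 2 in one place: bromo in place of methoxy on an aromatic carbon. Among the compounds with values here, no measured pair isolates this change, and the two measured values give no direction for it. For compound 3 the expected step is a 1.0-fold lower number from compound 2 to compound 3 (0.00 log units; within the scatter), which means no change beyond the scatter in either direction. Compound 3 is accordingly expected to give 2500 nM in this assay, with a range from 1000 nM to 6500 nM.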

Compound 3, half-maximal inhibitory concentration: 430 nM
For compound 3 the middle estimate is 5.8-fold (0.76 log units) above the measured one, outside the stated range (below it).
By their numbers in this assay, from the lowest: compound 3; then compounds 2 and 1 (each within the scatter of the next).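

In this assay, going by these compounds alone, 4-bromophenyl in place of 4-methoxyphenyl gives a 5.9-fold lower number from compound 2 to compound 3 (0.77 log units; beyond the scatter), the first change in a single place that can be read, and it lies beyond the scatter. This position, on an aromatic carbon of a six-membered aromatic ring of carbon only and para to a large group, therefore responds to the exchange of methoxy for bromo, something compound 1 and compound 2 could not show, as they differ in more than one place. Nothing measured here bears on the origin of the step.

This single pair cannot separate what the entry of bromo contributes from what the loss of methoxy contributes, and it gives one direction at one position only. As far as these compounds go, how chloro, an amine or a carboxylic acid would read at the same position remains open, as does whether the same exchange would give a step of similar size on a different member of the series.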